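Nitro for Methyl on the Aniline of Compound 2

The source may report more compounds than this note shows. Statements on the series, on what has been measured and on what is new or still open speak of the compounds shown alone.

In an assay on cell membranes for binding affinity to adenosine receptor A1 (Bos taurus), read by radioligand binding (on this read-out lower numbers stand for stronger inhibition and higher numbers for weaker inhibition), compound 1 `c1ccc(Cn2nnc3c(NC4CCCCC4)ncnc32)cc1` gives 121 nM, and compound 2 `Cc1cccc(Nc2ncnc3c2nnn3Cc2ccccc2)c1` gives 1100 nM, the higher of the two numbers. Among the measured compounds shown here, the only measured step is a 9.1-fold higher number from compound 1 to compound 2 (0.96 log units; beyond the scatter), which concerns a different part of the molecule. Compound 3 `O=[N+]([O-])c1cccc(Nc2ncnc3c2nnn3Cc2ccccc2)c1` carries nitro in place of methyl on an aromatic carbon. For the measured compounds named here, no measured step bears on an exchange of nitro for methyl, so nothing in the data points to a change beyond the scatter in this assay. Compound 3 is therefore expected at 1400 nM (range 400 nM to 5000 nM). The expected step is a 1.3-fold higher number from compound 2 to compound 3 (0.10 log units; within the scatter).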

Compound 3, inhibition constant: 443 nM
Compound 3: the middle estimate sits 3.2-fold (0.50 log units) above what was measured; the measured number falls inside the stated range.
By their numbers in this assay, from the lowest: compound 1; then compound 3; then compound 2.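

Nitro in place of methyl gives a 2.5-fold lower number from compound 2 to compound 3 (0.39 log units; beyond the scatter) in this assay, a modest change. Among the compounds shown here, this is the first sign that the aromatic carbon meta to a large group is not indifferent to what it carries, since the only earlier step concerned a different exchange on the same nitrogen. Nothing available gives a reason for this step. As far as these compounds go, whether the lower number is particular to nitro remains open, and an amine, a nitrile or a carboxylic acid on that carbon would test this. The compounds also leave open how a chlorine or a methoxy group would compare there.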